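This account rests on a few compounds, and the source may have more. Where it says the series, first, only, none or still open, it means among the compounds named here.

- Compound 1 `O=C1C(=Cc2ccc(Br)cc2)C(=O)N(c2ccc(Cl)cc2)N1c1ccc(Cl)cc1`: 16900 nM
- Compound 2 `COc1cccc(C=C2C(=O)N(c3ccc(Cl)cc3)N(c3ccc(Cl)cc3)C2=O)c1`: 26600 nM

Among the compounds with values here, in a functional assay on MGC-803 cells (Homo sapiens) for cytotoxicity, read by MTT assay, with a stated time of 72 h (on this read-out lower numbers stand for stronger inhibition and higher numbers for weaker inhibition), compound 2 gives 26600 nM, a value that cannot be separated from that of compound 1, the only other measured compound. The next structure is compound 3 `O=C1C(=Cc2ccc(Cl)cc2Cl)C(=O)N(c2ccc(Cl)cc2)N1c1ccc(Cl)cc1`, and the change is 2,4-dichlorophenyl in place of 3-methoxyphenyl on a double-bonded chain carbon bound to a double-bonded ring carbon. Within the data shown here, only one measured step bears on this place: a 1.6-fold higher number from compound 1 to compound 2 (0.20 log units; within the scatter). That step is small, so no step beyond the scatter is expected in this assay. The entering 2,4-dichlorophenyl carries halogen, as does the 4-bromophenyl of compound 1 at 16900 nM, which leans the expectation slightly towards that value. With a single step to go on, the range stays wide. The estimated step is a 1.5-fold lower number from compound 2 to compound 3 (0.17 log units; within the scatter), which would remain within the scatter. Compound 3 is expected at 18000 nM, with an estimated range of 7500 nM to 43000 nM.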

Compound 3, half-maximal inhibitory concentration: > 128000 nM
Compound 3 ended at the assay's limit; the forecaster's own chance of this, stated with the estimate: 4%; middle value at least 7.1-fold (0.85 log units) from the limit.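

In this assay, this position is not indifferent to the aryl group: the step of a 1.6-fold higher number from compound 1 to compound 2 (0.20 log units; within the scatter) gave no separation, whereas 2,4-dichlorophenyl gives an at least 4.8-fold higher number from compound 2 to compound 3 (0.68 log units; beyond the scatter) and an at least 7.5-fold higher number from compound 1 to compound 3 (0.87 log units; beyond the scatter). Halogen alone does not keep the values together, as 4-bromophenyl and 2,4-dichlorophenyl both carry halogen, yet compound 1 and compound 3 lie apart beyond the scatter. Compound 3 sits at a limit and has no exact value, so both new steps give only a minimum size: the limit of > 128000 nM in this assay, at which 1 of the 3 values shown sits.

The compounds shown do not separate the effect of having two chlorines from that of where they sit on the phenyl ring. Also open, from the compounds shown here alone, is whether a phenyl ring with a single chlorine, or one with an amine, would read close to compound 1 and compound 2 or would reach the same limit.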